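Dimethylamino for fluoro on the anilide ring of compound 2

The source may report more compounds than this note shows. Statements on the series, on what has been measured and on what is new or still open speak of the compounds shown alone.

Compound 1 `COc1cc(F)c(NC(=O)c2ccccn2)cc1Nc1nccc(-c2cn(C)c3ccccc23)n1` and compound 2 `COc1cc(F)c(NC(=O)c2ncccn2)cc1Nc1nccc(-c2cn(C)c3ccccc23)n1` differ only in the acyl group on the carbonyl carbon. In a functional assay on A549 cells (Homo sapiens) for antiproliferative activity, read by MTT assay, with a stated time of 72 h (a higher number here means a weaker inhibitor, a lower number a stronger inhibitor), compound 1 gives 7980 nM and compound 2 gives 8400 nM; the step of a 1.1-fold higher number from compound 1 to compound 2 (0.02 log units; within the scatter) is within the scatter, so the two stand together. Compound 2 holds the highest of the two numbers shown, with compound 1 as its nearest neighbour, and nothing separates them beyond noise.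

Compound 3 `COc1cc(N(C)C)c(NC(=O)c2ncccn2)cc1Nc1nccc(-c2cn(C)c3ccccc23)n1` follows from compound 2 by dimethylamino in place of fluoro on an aromatic carbon. The change sits on an aromatic carbon of a six-membered aromatic ring of carbon only, ortho to a ((pyrimidin-2-yl)carbonyl)amino group and meta to a methoxy group. For the measured compounds named here, no measured step touches this position: the single step recorded, from compound 1 to compound 2, concerns the acyl group and is itself within the scatter, so it gives no direction for the present change. The estimate therefore rests on compound 2 alone and carries a wide range; the expected step for compound 3 is a 2.1-fold lower number from compound 2 to compound 3 (0.32 log units; beyond the scatter), no firmer than that.

Compound 3 in this assay is estimated at 4000 nM, with a range of 800 nM to 20000 nM.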

Compound 3, half-maximal inhibitory concentration: 8640 nM
For compound 3 the middle estimate is 2.2-fold (0.33 log units) below the measured one; the measured number falls inside the stated range.
By their numbers in this assay, from the lowest: compounds 1, 2 and 3 (each within the scatter of the next).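

In this assay, for the compounds shown here, the step of a 1.0-fold higher number from compound 2 to compound 3 (0.01 log units; within the scatter) gives the first reading at this position, on an aromatic carbon ortho to a ((pyrimidin-2-yl)carbonyl)amino group and meta to a methoxy group: fluoro, with 1 heavy atom, gives way to dimethylamino, with 3 heavy atoms, and the two compounds stand together. Across the three compounds shown, neither the acyl change in a 1.1-fold higher number from compound 1 to compound 2 (0.02 log units; within the scatter) nor this change on the aromatic carbon separates a pair beyond the scatter, so the aromatic position is as flat so far as the acyl position, on the strength of one step each and with no compound going against it. Nothing available here speaks to why this replacement leaves the number in place.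

Still open, as far as these compounds go, is whether a longer chain ending in an amine, or a cyclic amine such as piperazine, on this aromatic carbon would give a number beyond the scatter of compound 3. Also open is whether dimethylamino behaves the same way alongside the pyridin-2-yl amide of compound 1, as the change is shown here only with the pyrimidin-2-yl amide.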